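This account rests on a few compounds, and the source may have more. Where it says the series, first, only, none or still open, it means among the compounds named here.

In an in vitro ADME assay on microsomes from liver (Homo sapiens) for metabolic stability (a higher number here means faster removal of the compound, a lower number slower removal), compound 3 `CC[C@@H](C)[C@@H]1C(=O)N[C@H](C2Cc3ccccc3C2)C(=O)N1[C@@H](C(=O)N1CCOCC1)c1ccc(C)nc1` gives 4 mL.min-1.g-1, the middle of three numbers, while compound 1 `CC[C@H](C)[C@@H]1C(=O)N[C@H](C2Cc3ccccc3C2)C(=O)N1[C@@H](C(=O)N1CCOCC1)c1cnc(C)cc1C` gives 1 mL.min-1.g-1 and compound 2 `CCC(CC)[C@@H]1C(=O)N[C@H](C2Cc3ccccc3C2)C(=O)N1[C@@H](C(=O)N1CCOCC1)c1ccc(C)nc1` gives 12 mL.min-1.g-1. Compound 4 `CC[C@H](C)[C@@H]1C(=O)N[C@H](C2Cc3ccccc3C2)C(=O)N1[C@@H](C(=O)N1CCOCC1)c1ccc(C)nc1` differs from compound 3 in one way: the two compounds have the same atoms and bonds and differ only in configuration as drawn: 1 of 4 stereo elements differ; a stereocentre at a saturated chain carbon is drawn R in compound 3 and S in compound 4. For the measured compounds named here, the only measured step that touches this chain is a 3.0-fold lower number from compound 2 to compound 3 (0.48 log units; beyond the scatter). Going by the values given here, that step changes the chain itself, and no measured pair shows what a change of configuration alone does. It therefore gives only a rough scale and no direction, so a change beyond the scatter is not expected. The expected step is no change at the digits printed from compound 3 to compound 4 (within the scatter). For compound 4, the estimated value is 4 mL.min-1.g-1, with an expected range from 1.5 mL.min-1.g-1 to 10 mL.min-1.g-1.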

Compound 4, intrinsic clearance in microsomes: 3 mL.min-1.g-1
Compound 4: the middle estimate sits 1.3-fold (0.12 log units) above what was measured, within the range that was stated.
By their numbers in this assay, from the lowest: compound 1; then compounds 4 and 3 (each within the scatter of the next); then compound 2.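

In this assay, for the compounds shown here, changing only the stereocentre at this saturated chain carbon from R to S gives a 1.3-fold lower number from compound 3 to compound 4 (0.12 log units; within the scatter), the first direct reading of configuration alone, and it shows no change beyond the scatter: the fact that compounds 3 and 4 differ only in the configuration as drawn. With the S configuration, sec-butyl in place of pentan-3-yl gives a 4.0-fold lower number from compound 2 to compound 4 (0.60 log units; beyond the scatter), the same direction as a 3.0-fold lower number from compound 2 to compound 3 (0.48 log units; beyond the scatter) with the R configuration. Hydrogen in place of methyl on an aromatic carbon gives a 3.0-fold higher number from compound 1 to compound 4 (0.48 log units; beyond the scatter), the first single-place step at that part of the molecule.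

From the compounds shown here alone, what a cyclopropyl group or a longer chain would do on this saturated ring carbon remains open. So does the effect of a methoxy group on that aromatic carbon.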